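A single ring swap in a sulfonamide series

This account rests on a few compounds, and the source may have more. Where it says the series, first, only, none or still open, it means among the compounds named here.

Three measured compounds share one core and differ only in the aromatic group that sits on a saturated chain carbon bound to an amine nitrogen. Compound 1 `O=S(=O)(NCCCNCc1cccc2ccccc12)c1cc(C(F)(F)F)cc(C(F)(F)F)c1` carries naphthalen-1-yl there; in a functional assay on HT-29 cells (Homo sapiens) for inhibition, read by MTT assay, with a stated time of 72 h (a lower number here means a stronger inhibitor of growth, a higher number a weaker inhibitor of growth), compound 1 gives 2600 nM. Compound 2 `O=S(=O)(NCCCNCc1ccc(Cl)cc1)c1cc(C(F)(F)F)cc(C(F)(F)F)c1` gives 2800 nM, and compound 3 `COc1ccc(CNCCCNS(=O)(=O)c2cc(C(F)(F)F)cc(C(F)(F)F)c2)cc1OC` gives 2700 nM. The three steps between them, a 1.1-fold higher number from compound 1 to compound 2 (0.03 log units; within the scatter), a 1.0-fold higher number from compound 1 to compound 3 (0.02 log units; within the scatter) and a 1.0-fold lower number from compound 2 to compound 3 (0.02 log units; within the scatter), all fall within the scatter, so compound 3, although nominally the second highest of the three numbers, cannot be told apart from either neighbour.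

Compound 4 `CC(C)(C)c1ccc(CNCCCNS(=O)(=O)c2cc(C(F)(F)F)cc(C(F)(F)F)c2)cc1` is the next member. Its change from compound 3 is 4-(tert-butyl)phenyl in place of 3,4-dimethoxyphenyl on a saturated chain carbon bound to an amine nitrogen. Every measured step bears on this change, since each one also exchanged the aromatic group in that same place, and none of them moved the number beyond the scatter. The tert-butyl group has not yet been tried, but on the evidence of compound 1, compound 2 and compound 3, no step beyond the scatter is expected in this assay in either direction.

Compound 4 is therefore estimated at 2700 nM, within a range from 1300 nM to 5500 nM. The expected step is no change at the digits printed from compound 3 to compound 4 (within the scatter).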

Compound 4, concentration for 50% growth inhibition: 2000 nM
Estimate against measurement, compound 4: 1.4-fold (0.13 log units) above; the range from low to high includes it.
By their numbers in this assay, from the lowest: compounds 4, 1, 3 and 2 (each within the scatter of the next).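

Replacing 3,4-dimethoxyphenyl, which has two hydrogen-bond acceptors, with the all-carbon 4-(tert-butyl)phenyl, which has none and the same number of heavy atoms, gives a 1.4-fold lower number from compound 3 to compound 4 (0.13 log units; within the scatter) in this assay. The remaining comparisons agree: tert-butyl in place of chloro on an aromatic carbon gives a 1.4-fold lower number from compound 2 to compound 4 (0.15 log units; within the scatter), and 4-(tert-butyl)phenyl in place of naphthalen-1-yl gives a 1.3-fold lower number from compound 1 to compound 4 (0.11 log units; within the scatter), so in these four compounds, hydrogen-bond acceptors on this aromatic group are not needed to keep the number within the scatter of the others. Nothing measured here explains this lack of separation.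

On these data alone, all four compounds carry a carbon-only aromatic ring at this place, so it remains open whether the number would hold with a carboxylic acid or an amine on that ring, or with a longer saturated chain in place of the ring. Within the data shown here, it is also open whether any change here can move the number beyond the scatter, as every step so far lies within it.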